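The compounds below may be only part of what the source reports. "The series", "measured", "known", "first", "only" and "open" are said of these compounds alone.

Measured so far in an ADME assay on Huh-7 cells (Homo sapiens) for cytotoxicity; on this read-out lower numbers stand for stronger inhibition and higher numbers for weaker inhibition:
- compound 1 `CN(c1cc2ncc(=O)[nH]c2cc1NC(=S)NC(=O)c1ccccc1)C1CCCCC1`: 11100 nM
- compound 2 `CN(c1cc2ncc(=O)[nH]c2cc1NC(=S)NC(=O)c1ccc(Cl)nc1)C1CCCCC1`: 34500 nM

Compound 1 has the lowest of the two numbers; its nearest neighbour is compound 2, and the step of a 3.1-fold higher number from compound 1 to compound 2 (0.49 log units; beyond the scatter) is the only one measured in the series. That step exchanges the ring on the carbonyl carbon and leaves the acyl thiourea linkage intact.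

Compound 3 `CN(c1cc2ncc(=O)[nH]c2cc1NC(=S)Nc1cccc2ccccc12)C1CCCCC1` is not yet measured. It differs from compound 1 in one place: naphthalen-1-yl in place of benzoyl on an amide-type nitrogen. The change removes the benzoyl group together with its carbonyl from the amide-type nitrogen and puts a naphthalen-1-yl directly on that nitrogen; the shared core and the cyclohexyl(methyl)amino substituent are unchanged.

Among the measured compounds shown here, no measured step covers this kind of change. For the measured compounds named here, the single step from compound 1 to compound 2 concerns a different part of the molecule and only shows that swapping one aromatic ring for another at the carbonyl moves this assay by a modest amount. For compound 3 the step of a 1.4-fold lower number from compound 1 to compound 3 (0.14 log units; within the scatter) is therefore expected to be small, with a wide range in both directions.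

The estimate for compound 3 in this assay is 8000 nM (range 2500 nM to 25000 nM).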

Compound 3, half-maximal inhibitory concentration: 43600 nM
Compound 3: the middle estimate sits 5.5-fold (0.74 log units) below what was measured, and the stated range ends below it.
By their numbers in this assay, from the lowest: compound 1; then compounds 2 and 3 (each within the scatter of the next).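

In this assay the position on the amide-type nitrogen also responds when the carbonyl goes: replacing benzoyl with naphthalen-1-yl gives a 3.9-fold higher number from compound 1 to compound 3 (0.59 log units; beyond the scatter) and so breaks the acyl thiourea linkage, which the earlier step left intact. Exchanging (6-chloropyridin-3-yl)carbonyl for naphthalen-1-yl gives a 1.3-fold higher number from compound 2 to compound 3 (0.10 log units; within the scatter) and so leaves these two groups unseparated on this read-out, even though one keeps the carbonyl and the other does not. Benzoyl therefore stands apart from both other groups at this position, and no supporting measurement bears on the reason for either step.

The compounds shown leave open whether the step away from benzoyl follows the loss of the carbonyl or the change from one six-membered aromatic ring to two, as the two changes occur together in compound 3. Also open, from the compounds shown here alone, is how a benzyl group, a longer alkyl chain or a chain ending in an amine on the same nitrogen would read in this assay alongside these three compounds.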